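The source may report more compounds than this note shows. Statements on the series, on what has been measured and on what is new or still open speak of the compounds shown alone.

Measured so far:
compound 1, `Cc1cccc(NC(=O)N[C@H](C)c2ccccc2)c1`, 100%
compound 2, `C[C@@H](NC(=O)Nc1cccc(Cl)c1)c1ccccc1`, 97%

Both compounds were tested in an ADME assay on the whole organism with Oryza sativa as the target, tested at 0.1 uM; on this read-out lower numbers stand for a stronger effect and higher numbers for a weaker effect at the one concentration tested. Compound 1 gives 100% and compound 2 gives 97%. The step between them, a number 3 percentage points lower from compound 1 to compound 2 (within the scatter), comes with chloro in place of methyl on an aromatic carbon. On these two numbers compound 2 stands right beside compound 1: the gap is within the scatter, so the two readings cannot be told apart.

Compound 3, `C[C@@H](NC(=O)Nc1cccc(Br)c1)c1ccccc1`, has not yet been measured. It differs from compound 2 in one place: bromo in place of chloro on an aromatic carbon. Among the compounds with values here, the only measured step that bears on this change is the one between compound 1 and compound 2, a number 3 percentage points lower from compound 1 to compound 2 (within the scatter), where one small group on an aromatic carbon replaced another and the number hardly moved. A further exchange of one small group for another on an aromatic carbon is therefore expected to give no step beyond the scatter; the estimated change is a number 1 percentage points lower from compound 2 to compound 3 (within the scatter). Compound 3 is expected to give about 96% in this assay, with a likely range from 85% to 100%.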

Compound 3, a percentage reported as activity, at one concentration (the size of the read-out at that concentration, not a potency): 100%
Compound 3: the middle estimate sits 4 percentage points below what was measured; low and high end bracket the measured number.
By their numbers in this assay, from the lowest: compounds 2, 1 and 3 (each within the scatter of the next).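

Bromo in place of chloro on this aromatic carbon, meta to a large group, gives a number 3 percentage points higher from compound 2 to compound 3 (within the scatter) in this assay and so adds a second halogen exchange that leaves the reading inside the usual noise. The other new comparison, bromo in place of methyl, gives no change at the digits printed from compound 1 to compound 3 (within the scatter) and shows that the two groups at the far ends of this small series also cannot be told apart, so methyl, chloro and bromo all read alike at this position in these three compounds. No measurement at hand offers a reason for this sameness.

The compounds shown leave open whether a group of a different kind at this place, such as an amine, a carboxylic acid or a longer chain, would move the number beyond the scatter. They also leave open whether the same exchanges on another carbon of that ring would read alike, and how these compounds would compare at any other concentration.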